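The compounds below may be only part of what the source reports. "The series", "measured", "known", "first", "only" and "open" are said of these compounds alone.

Series notes. Compound 1 `CN(C)CCn1cnnc1-c1cc(Oc2ccc(NC(=O)N/N=C/c3ccc(Cl)cc3Cl)cc2F)ccn1` gives 2330 nM in a functional assay on U-87MG ATCC cells (Homo sapiens) for cytotoxicity, read by MTT assay, with a stated time of 72 h; a lower number here means a stronger inhibitor, a higher number a weaker inhibitor. Compound 2 `CN(C)CCn1cnnc1-c1cc(Oc2ccc(NC(=O)N/N=C/c3ccccc3)cc2F)ccn1` gives 2250 nM in this assay. Compound 3 `COc1ccc(/C=N/NC(=O)Nc2ccc(Oc3ccnc(-c4nncn4CCN(C)C)c3)c(F)c2)cc1O` reaches only the assay limit of > 100000 nM in this assay; this is a limit, not a number. Among the two numbers shown, compound 2 carries the lowest, with compound 1 within the scatter of it.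

Compound 4 `Cc1cc(/C=N/NC(=O)Nc2ccc(Oc3ccnc(-c4nncn4CCN(C)C)c3)c(F)c2)cc(C)c1O` is not yet measured. It differs from compound 2 by 4-hydroxy-3,5-dimethylphenyl in place of phenyl on a carbon with a double bond to nitrogen.

Bearing on this step: a 1.0-fold lower number from compound 1 to compound 2 (0.02 log units; within the scatter), and the two steps to the aryl bearing a hydroxyl and a methoxy, an at least 42-fold higher number from compound 1 to compound 3 (1.63 log units; beyond the scatter) and an at least 44-fold higher number from compound 2 to compound 3 (1.64 log units; beyond the scatter), the latter two set by the limit of > 100000 nM in this assay, at which 1 of the 3 values shown sits. The entering group of compound 4 also carries a hydroxyl, so a sizeable rise in the number is expected, though with two methyls rather than a methoxy the size cannot be fixed from compound 3 alone. The step from compound 2 is estimated at a 13-fold higher number from compound 2 to compound 4 (1.12 log units; beyond the scatter). Compound 4 is expected at 30000 nM, within 5000 nM to 150000 nM.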

Compound 4, half-maximal inhibitory concentration: 7710 nM
Estimate against measurement, compound 4: 3.9-fold (0.59 log units) above; the range from low to high includes it.
By their numbers in this assay, from the lowest: compounds 2 and 1 (each within the scatter of the next); then compound 4. At a limit, above all of these: compound 3.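

In this assay, a hydroxyl on this aryl does not always bring a loss as large as that seen with compound 3: the 4-hydroxy-3,5-dimethylphenyl group gives a 3.4-fold higher number from compound 2 to compound 4 (0.53 log units; beyond the scatter) and a 3.3-fold higher number from compound 1 to compound 4 (0.52 log units; beyond the scatter), both modest steps. The value of compound 3 is a limit and not a number: the limit of > 100000 nM in this assay, at which 1 of the 4 values shown sits. Read against that limit, exchanging one hydroxyl-bearing aryl for the other gives an at least 12-fold lower number from compound 3 to compound 4 (1.11 log units; beyond the scatter), so the outcome at this position depends on more than the presence of a hydroxyl.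

The two hydroxyl-bearing groups differ both in where the hydroxyl sits and in methyls against a methoxy, and the compounds shown do not separate these two changes. Also open, going by these compounds, is how an amine or a carboxylic acid on this aryl would compare with the unsubstituted phenyl.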